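The compounds below may be only part of what the source reports. "The series", "measured", "known", "first", "only" and "open" are said of these compounds alone.

Compound 1 `COc1cc2c(Oc3ccc(NC(=O)c4nn(-c5ccccc5C(F)(F)F)c(=O)cc4C)cc3F)ccnc2cc1OCCCN1CCC(C)CC1`: 160 nM
Compound 2 `COc1cc2c(Oc3ccc(NC(=O)c4nn(-c5cccc(F)c5)c(=O)cc4C)cc3F)ccnc2cc1OCCCN1CCCCC1`: 250 nM
Compound 3 `COc1cc2c(Oc3ccc(NC(=O)c4nn(-c5cccc(F)c5)c(=O)cc4C)cc3F)ccnc2cc1OCCCN1CCC(C)CC1`: 250 nM

All three numbers come from a functional assay on A549 cells (Homo sapiens) for inhibition, read by MTT assay, with a stated time of 72 h; on this read-out lower numbers stand for stronger inhibition and higher numbers for weaker inhibition. Compound 3 stands level with compound 2, and the step of a 1.6-fold higher number from compound 1 to compound 3 (0.19 log units; within the scatter) lies within the scatter, so the three compounds are not separable on these numbers. Compound 4 `COc1cc2c(Oc3ccc(NC(=O)c4nn(-c5ccc(Cl)cc5Cl)c(=O)cc4C)cc3F)ccnc2cc1OCCCN1CCC(C)CC1` differs from compound 3 by 2,4-dichlorophenyl in place of 3-fluorophenyl on an aromatic nitrogen. Among the measured compounds shown here, the one measured step that bears on the group on that aromatic nitrogen is a 1.6-fold higher number from compound 1 to compound 3 (0.19 log units; within the scatter), where one aryl group replaced another without a change beyond the scatter. The methyl-for-hydrogen step no change at the digits printed from compound 2 to compound 3 (within the scatter) was likewise flat. The expected step of a 1.3-fold lower number from compound 3 to compound 4 (0.10 log units; within the scatter) is therefore none beyond the scatter. Compound 4 is estimated at 200 nM, with a range of 80 nM to 500 nM.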

Compound 4, half-maximal inhibitory concentration: 200 nM
Estimate against measurement, compound 4: no gap at the digits printed, within the range that was stated.
By their numbers in this assay, from the lowest: compounds 1, 4, 2 and 3 (each within the scatter of the next).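

On the aromatic nitrogen, this assay now covers a third aryl group, one with two chlorines, and the steps of a 1.3-fold lower number from compound 3 to compound 4 (0.10 log units; within the scatter) and a 1.3-fold higher number from compound 1 to compound 4 (0.10 log units; within the scatter) both stay within the scatter. 2,4-Dichlorophenyl therefore cannot be separated from 3-fluorophenyl or 2-(trifluoromethyl)phenyl, so the flat reading at this position extends to a phenyl ring with two substituents. No measurement at hand accounts for this flat response. Still open, as far as these compounds go, is whether a cyclohexyl ring or a simple methyl group on this nitrogen, or a phenyl ring bearing an amine or a carboxylic acid, would give a step beyond the scatter.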